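A few compounds are considered here, and "the series" means these few. Any claim that something is new, unique, unknown or untested is made for them only; others in the source may bear on it.

Four curcumin-like compounds share a core in which two aromatic rings are joined through a chain carrying a carbonyl and two double bonds. Compound 1 `O=C(/C=C/c1cccc(O)c1)/C=C/c1ccc(O)c(O)c1` gives 71000 nM in a functional assay, with a stated time of 30 min; a higher number here means a weaker inhibitor, a lower number a stronger inhibitor. Compound 2 `O=C(/C=C/c1ccc(O)cc1)/C=C/c1ccc(O)c(O)c1` differs from it by 4-hydroxyphenyl in place of 3-hydroxyphenyl on a double-bonded chain carbon bound to a double-bonded chain carbon, and in this assay compound 2 gives 24000 nM, which is a 3.0-fold lower number from compound 1 to compound 2 (0.47 log units; beyond the scatter). Compound 3 `O=C(/C=C/c1cccc(O)c1)/C=C/c1cccc(O)c1O` carries a different core from compound 1; the difference between the two cores is not broken down here. In this assay compound 3 gives 48000 nM, which lies within the scatter of the numbers for compound 1 and compound 2.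

Compound 4 `O=C(/C=C/c1ccc(O)cc1)/C=C/c1cccc(O)c1O` has not yet been measured. It differs from compound 3 by 4-hydroxyphenyl in place of 3-hydroxyphenyl on a double-bonded chain carbon bound to a double-bonded chain carbon, the same change that turns compound 1 into compound 2, made at the same place. If this change behaves on the core of compound 3 as it did on the core of compound 1, the step from compound 3 to compound 4 is expected to be a 3.0-fold lower number from compound 3 to compound 4 (0.48 log units; beyond the scatter), because a 3.0-fold lower number from compound 1 to compound 2 (0.47 log units; beyond the scatter). The expectation for compound 4 in this assay is therefore 16000 nM, with a range from 7000 nM to 40000 nM, resting on a single earlier instance of the change.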

Compound 4, half-maximal inhibitory concentration: 40000 nM
For compound 4 the middle estimate is 2.5-fold (0.40 log units) below the measured one; low and high end bracket the measured number.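

On the core of compound 3, 4-hydroxyphenyl in place of 3-hydroxyphenyl on a double-bonded chain carbon bound to a double-bonded chain carbon gives, in this assay, a 1.2-fold lower number from compound 3 to compound 4 (0.08 log units; within the scatter), a step too small to tell apart from no change at all. Set beside the earlier step, this one does not differ from it by more than repeated measurements could explain: the same change on two cores in this assay, a 3.0-fold lower number (0.47 log units; beyond the scatter) from compound 1 to compound 2 and a 1.2-fold lower number (0.08 log units; within the scatter) from compound 3 to compound 4, 2.5-fold (0.39 log units) apart, within the scatter of two such steps. The change may therefore carry over from one core to the other with the same size, or it may carry over only in part; with a single pair on each core, these data show neither a transfer nor a failure to transfer.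

As far as these compounds go, all four compounds carry only hydroxyl groups on their aromatic rings, so it remains open how a methoxy group, an amine or a carboxylic acid in their place would behave on either core. From the compounds shown here alone, it is also open whether a longer chain between the rings would leave this step as it stands.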